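The source may report more compounds than this note shows. Statements on the series, on what has been measured and on what is new or still open speak of the compounds shown alone.

In a functional assay on HepG2 cells (Homo sapiens) for antiproliferative activity, read by MTT assay (a higher number here means a weaker inhibitor, a lower number a stronger inhibitor), compound 1 (`CN1CCC(=O)/C(=C/c2ccc(OC3CCCC3)cc2)C1`) gives 15900 nM and compound 2 (`Cc1ccc(C2=NN(c3ccccc3)C(c3ccc(OC4CCCC4)cc3)C2)cc1`) gives 7200 nM. Compound 1 therefore has the higher of the two numbers and is the weaker inhibitor, by a gap just beyond the usual scatter. Compound 3 (`CCN1CCC(=O)/C(=C/c2ccc(OC3CCCC3)cc2)C1`) differs from compound 1 by one change (methyl in place of hydrogen on a saturated chain carbon bound to an amine nitrogen in a ring): methyl in place of hydrogen on a saturated chain carbon bound to an amine nitrogen in a ring. Going by the values given here, no measured pair shows this change, so no step beyond the scatter is expected (a 1.1-fold lower number from compound 1 to compound 3 (0.06 log units; within the scatter)). Compound 3 is estimated at 14000 nM (expected range 6000 nM to 30000 nM).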

Compound 3, half-maximal inhibitory concentration: 13000 nM
Beside the measured number, compound 3's estimate is 1.1-fold (0.03 log units) above it; measured number inside the range.
By their numbers in this assay, from the lowest: compounds 2, 3 and 1 (each within the scatter of the next, the first and the last beyond it).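

In this assay, methyl in place of hydrogen on a saturated chain carbon bound to an amine nitrogen in a ring, which reads as methyl to ethyl, gives a 1.2-fold lower number from compound 1 to compound 3 (0.09 log units; within the scatter). This first pair differing in one place shows that this single added carbon leaves the number within the scatter. No measurement shown offers an explanation for this result. From the compounds shown here alone, whether a propyl chain, a benzyl group or a carboxylic acid at this position would move the number beyond the scatter remains open.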